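Series notes: methoxy in place of chloro on the fused ring

This account rests on a few compounds, and the source may have more. Where it says the series, first, only, none or still open, it means among the compounds named here.

Compound 1 `COc1c(/C=C2/C(=O)Nc3ccccc32)c2ccccc2n1-c1ccccc1` and compound 2 `COc1c(/C=C2/C(=O)Nc3ccc(Cl)cc32)c2ccccc2n1-c1ccccc1` share one core and differ at a single aromatic carbon. In a functional assay on NSCLC cells (Homo sapiens) for cytotoxicity, with a stated time of 48 h (a higher number here means a weaker inhibitor of growth, a lower number a stronger inhibitor of growth), compound 1 gives 2140 nM, while compound 2 gives 9550 nM. The step between them, a 4.5-fold higher number from compound 1 to compound 2 (0.65 log units; beyond the scatter), is beyond the scatter and modest in size. Going by the values given here, compound 2 therefore holds the higher of the two values so far, with compound 1 as its only neighbour at the lower number.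

Compound 3 `COc1ccc2c(c1)/C(=C\c1c(OC)n(-c3ccccc3)c3ccccc13)C(=O)N2` is the next member and remains unmeasured. Its change from compound 2 is methoxy in place of chloro on an aromatic carbon. Among the compounds with values here, the only measured step that bears on this position is a 4.5-fold higher number from compound 1 to compound 2 (0.65 log units; beyond the scatter), in which chloro replaced hydrogen and the number rose modestly. Within the data shown here, no measured pair places methoxy at this carbon, so the direction of the present change is open; a shift of modest size in either direction, or none beyond the scatter, is plausible, and a value between those of compound 1 and compound 2 seems most likely. Compound 3 is expected to give 5000 nM in this assay, with a range from 1500 nM to 15000 nM, corresponding to an expected step of a 1.9-fold lower number from compound 2 to compound 3 (0.28 log units; within the scatter).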

Compound 3, concentration for 50% growth inhibition: 2510 nM
For compound 3 the middle estimate is 2.0-fold (0.30 log units) above the measured one; the measured number falls inside the stated range.
By their numbers in this assay, from the lowest: compounds 1 and 3 (each within the scatter of the next); then compound 2.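

In this assay this aromatic carbon accepts methoxy with a 1.2-fold higher number from compound 1 to compound 3 (0.07 log units; within the scatter) for the change from hydrogen, a step that stays within the scatter and contrasts with a 4.5-fold higher number from compound 1 to compound 2 (0.65 log units; beyond the scatter) for chloro in place of hydrogen. The direct exchange gives a 3.8-fold lower number from compound 2 to compound 3 (0.58 log units; beyond the scatter) on going from chloro to methoxy, so the rise seen with chloro does not follow from simply placing a group at this carbon: of the two groups shown here, only chloro moves the number beyond the scatter relative to hydrogen. Nothing among the available data explains why chloro and methoxy part in this way.

Still open, going by these compounds, is whether an amine, a carboxylic acid or a longer chain such as ethoxy at this carbon would stay within the scatter of hydrogen, as methoxy does, or shift the number as chloro does. Also open, on these data alone, is whether the contrast between chloro and methoxy would hold with the same groups on another carbon of this ring or with a different group in place of the phenyl on the shared core.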